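The source may report more compounds than this note shows. Statements on the series, on what has been measured and on what is new or still open speak of the compounds shown alone.

For the measured compounds named here, compound 1, `O=C(NO)c1cccc(-c2cn([C@H]3C[C@@H](C(=O)O)N(Cc4ccccc4)C3)nn2)c1`, is the only compound here with a numerical read-out: in an assay on Sf9 cells for inhibition of histone deacetylase 11 (Homo sapiens), read by fluorescence, tested at 0.5 uM (a higher number here means more inhibition at the concentration tested (going by the name of the read-out), a lower number less inhibition), compound 1 gives 14%. Compound 2, `O=C(NO)c1cccc(-c2cn([C@@H]3C[C@@H](C(=O)O)N(Cc4ccccc4)C3)nn2)c1`, is reported at a limit of the assay, < 10%. Compound 3, `O=C(NO)c1cccc(-c2cn([C@H]3C[C@@H](CO)N(Cc4ccccc4)C3)nn2)c1`, likewise sits at a limit, < 10%. The step of a number at least 4 percentage points lower from compound 1 to compound 2 (that floor lies within the scatter) and the step of a number at least 4 percentage points lower from compound 1 to compound 3 (that floor lies within the scatter) both stay within the usual scatter; the limit of < 10% in this assay, at which 2 of the 3 values shown sit, leaves their true size open. Compound 4, `O=C(NO)c1cccc(-c2cn([C@H]3C[C@@H](C(=O)O)N(CCCc4ccccc4)C3)nn2)c1`, differs from compound 1 by phenethyl in place of phenyl on a saturated chain carbon bound to an amine nitrogen in a ring. Neither measured step touches that part of the molecule, so no shift beyond the scatter is expected. Compound 4 is therefore estimated at 14%, between 5% and 25%. That is an expected step of no change at the digits printed from compound 1 to compound 4 (within the scatter), within the scatter.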

Compound 4, a percentage reported as inhibition, at one concentration (the size of the read-out at that concentration, not a potency): < 10%
Compound 4: a limit, no number; the forecaster's own chance of this, stated with the estimate: 35%; middle value at least 4 percentage points away from the limit.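

For the compounds shown here, compound 4 is the first change at the amine nitrogen in a ring, where benzyl gives way to 3-phenylpropyl, and in this assay the result is a number at least 4 percentage points lower from compound 1 to compound 4 (that floor lies within the scatter). Lengthening this chain therefore brings no visible gain in inhibition, but no loss beyond the scatter can be claimed either. The size of the step stays unsettled: the limit of < 10% in this assay, at which 3 of the 4 values shown sit.

Still open, as far as these compounds go, is whether another group on this nitrogen, such as a plain methyl or a pyridylmethyl, would lift inhibition clear of the scatter. Also open, from the compounds shown here alone, is whether 3-phenylpropyl would behave the same way on the core of compound 2.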